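Two Hydroxyls Replace a Fluorine on the Hydrazone Arm

The source may report more compounds than this note shows. Statements on the series, on what has been measured and on what is new or still open speak of the compounds shown alone.

Of the compounds shown here, three sharing one core have been tested so far. Compound 1 `CN(C)CCn1cnnc1-c1cc(Oc2ccc(NC(=O)N/N=C/c3c[nH]c4ccccc34)cc2F)ccn1` gives 790 nM in a functional assay on MKN-45 cells (Homo sapiens) for cytotoxicity, read by MTT assay, with a stated time of 72 h; on this read-out higher numbers stand for weaker inhibition and lower numbers for stronger inhibition. Compound 2 `CN(C)CCn1cnnc1-c1cc(Oc2ccc(NC(=O)N/N=C/c3ccc(F)cc3)cc2F)ccn1` gives 1030 nM, and compound 3 `CN(C)CCn1cnnc1-c1cc(Oc2ccc(NC(=O)N/N=C/c3c(O)ccc4ccccc34)cc2F)ccn1` gives 2020 nM. The change from compound 1 to compound 2 produced a 1.3-fold higher number from compound 1 to compound 2 (0.12 log units; within the scatter), while from compound 1 to compound 3 it was a 2.6-fold higher number from compound 1 to compound 3 (0.41 log units; beyond the scatter) and from compound 2 to compound 3 a 2.0-fold higher number from compound 2 to compound 3 (0.29 log units; within the scatter). Compound 2 therefore sits second highest of the three numbers, close to compound 1 and somewhat further from compound 3.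

The next compound, compound 4 `CN(C)CCn1cnnc1-c1cc(Oc2ccc(NC(=O)N/N=C/c3ccc(O)cc3O)cc2F)ccn1`, differs from compound 2 in one place: 2,4-dihydroxyphenyl in place of 4-fluorophenyl on a carbon with a double bond to nitrogen. Among the compounds with values here, the only measured step that bears on this is the one from compound 2 to compound 3, where a group carrying a hydroxyl replaced the 4-fluorophenyl and the number rose by an amount within the scatter. On that basis the expected change for compound 4 is small, a 1.5-fold higher number from compound 2 to compound 4 (0.16 log units; within the scatter), if anything toward a higher number. Compound 4 is thus estimated at 1500 nM, with a range from 600 nM to 4000 nM.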

Compound 4, half-maximal inhibitory concentration: 2860 nM
Beside the measured number, compound 4's estimate is 1.9-fold (0.28 log units) below it, and the stated range covers the measured number.
By their numbers in this assay, from the lowest: compounds 1, 2, 3 and 4 (each within the scatter of the next, the first and the last beyond it).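

Replacing 4-fluorophenyl with 2,4-dihydroxyphenyl gives a 2.8-fold higher number from compound 2 to compound 4 (0.44 log units; beyond the scatter), so a swap between two groups that each hold one six-membered aromatic ring of carbon only can move the number beyond the scatter at this position. The two hydroxyl-bearing groups cannot be told apart, with a 1.4-fold higher number from compound 3 to compound 4 (0.15 log units; within the scatter), while the gap to the 1H-indol-3-yl group reaches a 3.6-fold higher number from compound 1 to compound 4 (0.56 log units; beyond the scatter). Nothing available here explains the size of these steps.

The compounds shown leave open whether both hydroxyl groups are needed for this rise or whether a phenyl ring with a single hydroxyl would give the same number. They also leave open how a methoxy group, an amine or a carboxylic acid on that ring would compare.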